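The source may hold more compounds than are shown below. What is called first, only, known or untested is meant among the compounds shown, and "the series" means these compounds.

Compound 1 `Cc1c(Cc2c(F)cccc2F)nc(SCc2ccccc2)[nH]c1=O`: > 70000 nM
Compound 2 `Cc1c(Cc2c(F)cccc2F)nc(SCc2ccc([N+](=O)[O-])cc2)[nH]c1=O`: > 37000 nM
Compound 3 `Cc1c(Cc2c(F)cccc2F)nc(SC(C)C)[nH]c1=O`: > 77000 nM

All three entries come from an ADME assay on MT4 cells (Homo sapiens) for cytotoxicity, read by MTT assay (a higher number here means that more compound is tolerated, a lower number that less compound is tolerated), and none of them is a number. Compound 3 stands only at a limit, > 77000 nM. The other two compounds give limits as well, so compound 3 cannot be ranked against them.

Compound 4 `Cc1c(Cc2c(F)cccc2F)nc(SCC(=O)c2ccccc2)[nH]c1=O` has not yet been measured. Its difference from compound 3 is this: benzoylmethyl in place of isopropyl on a sulfur. In words, it is benzoylmethyl in place of isopropyl on a sulfur.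

Within the data shown here, two measured steps bear on the change. The closer one is a step that the two limits leave unreadable from compound 1 to compound 3, which also alters the group on the sulfur. The other is a step that the two limits leave unreadable from compound 1 to compound 2, with nitro in place of hydrogen on an aromatic carbon. Neither has a readable size, so no step beyond the scatter can be predicted in this assay, and no direction can be given.

Compound 1, which carries benzyl on the sulfur, sits at the limit > 70000 nM. Compound 2, which also carries an aromatic ring in that group, sits at the limit > 37000 nM. Another limit is therefore the likeliest report for the new compound.

Compound 4 is expected at about 55000 nM, with an estimated range from 20000 nM to 90000 nM. The expected step is an at least 1.4-fold lower number from compound 3 to compound 4 (0.14 log units; that floor lies within the scatter).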

Compound 4, half-maximal cytotoxic concentration: 65000 nM
Beside the measured number, compound 4's estimate is 1.2-fold (0.07 log units) below it; low and high end bracket the measured number.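

In this assay, among these compounds, compound 4 gives 65000 nM, which is a number and not a limit, so this is the first group on the sulfur to yield a readable value. The change from isopropyl to benzoylmethyl comes out as an at least 1.1-fold lower number from compound 3 to compound 4 (0.07 log units; that floor lies within the scatter), and benzoyl in place of phenyl on the saturated chain carbon bound to the sulfur comes out as an at least 1.0-fold lower number from compound 1 to compound 4 (0.03 log units; that floor lies within the scatter); both are only floors, so these compounds show no step beyond the scatter at this position, though a larger step is not excluded. Compound 2 stands at a limit, so its step to compound 4 cannot be read: the limit of > 37000 nM in this assay, at which 1 of the 4 values shown sits.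

The compounds shown leave open how far the true values of compound 1 and compound 3 lie from that of compound 4, and so whether the carbonyl in the benzoylmethyl chain matters at all in this assay. They also leave open whether a chain on the sulfur ending in an amine or a carboxylic acid, or a longer chain between the sulfur and the phenyl ring, would give a step beyond the scatter.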